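Bis-ring acid series: arylthio in place of phenoxy

The source may report more compounds than this note shows. Statements on the series, on what has been measured and on what is new or still open speak of the compounds shown alone.

Measured compounds:
compound 1 `O=C(O)CC/C=C\CC1COC(c2ccc3ccccc3c2)OC1c1cccnc1` — 1780 nM
compound 2 `CC(C)(Oc1ccccc1)C1OCC(C/C=C\CCC(=O)O)C(c2cccnc2)O1` — 75.9 nM

For the measured compounds named here, in a functional assay for inhibition, with Homo sapiens as the target (on this read-out lower numbers stand for tighter binding and higher numbers for weaker binding), compound 2 gives the lowest of the two numbers; the nearest is compound 1, whose step a 23-fold lower number from compound 1 to compound 2 (1.37 log units; beyond the scatter) is the only measured step in the set. Going by the values given here, that step sits on the saturated ring carbon of the shared core and exchanged one group for another at that very place, so it is the one step that bears on what follows.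

Compound 3 `Cc1ccc(SC(C)(C)C2OCC(C/C=C\CCC(=O)O)C(c3cccnc3)O2)c([N+](=O)[O-])c1` is not yet measured. It differs from compound 2 in this way: a group of 11 heavy atoms (7 carbon, 1 nitrogen, 2 oxygen, 1 sulfur; one six-membered aromatic ring of carbon only) in place of a group of 7 heavy atoms (6 carbon, 1 oxygen; one six-membered aromatic ring of carbon only), on a saturated chain carbon bound to two saturated chain carbons and a saturated ring carbon. Among the compounds with values here, the change again touches the substituent hanging off the core, though now at the saturated chain carbon, and no measured pair shows what the entering group does. Within the data shown here, with only one step known, and that step going in the direction of tighter binding as the group at the core was varied, the size of the step from compound 2 to compound 3 is expected to be small, a 1.1-fold higher number from compound 2 to compound 3 (0.02 log units; within the scatter), with no clear direction beyond the scatter. Compound 3 is therefore estimated at 80 nM, within 20 nM to 320 nM.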

Compound 3, dissociation constant: 158 nM
Beside the measured number, compound 3's estimate is 2.0-fold (0.30 log units) below it; low and high end bracket the measured number.
By their numbers in this assay, from the lowest: compound 2; then compound 3; then compound 1.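

In this assay, for the compounds shown here, the first measured change at the saturated chain carbon bound to two saturated chain carbons and a saturated ring carbon gives a 2.1-fold higher number from compound 2 to compound 3 (0.32 log units; beyond the scatter). Phenoxy can therefore give way to the group of 11 heavy atoms, with sulfur in place of oxygen and a ring that carries methyl and nitro, at a modest cost that lies beyond the scatter. Against the large 23-fold lower number from compound 1 to compound 2 (1.37 log units; beyond the scatter), made at the saturated ring carbon, this change within the substituent moves the number far less, and no measurement on hand bears on the reason for the step.

The single step changes the linking atom and the ring substituents together, so the compounds shown do not divide it among sulfur, nitro and methyl. From the compounds shown here alone, whether a plain phenylthio group, or a phenoxy group carrying only a nitro group, would stand nearer to compound 2 or to compound 3 remains open.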